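Three Amides in a Cell Inhibition Assay

A few compounds are considered here, and "the series" means these few. Any claim that something is new, unique, unknown or untested is made for them only; others in the source may bear on it.

Compound 1 `C=CC(=O)Nc1cccc(-c2nc3ccccc3s2)c1`: > 25000 nM
Compound 2 `C=C(C)C(=O)Nc1cccc(-c2nc3ccccc3s2)c1`: > 25000 nM

In an ADME assay on BJ cells (Homo sapiens) for inhibition, with a stated time of 72 h (on this read-out higher numbers stand for an effect only at larger amounts of compound and lower numbers for an effect already at smaller amounts), compound 1 reaches only the assay limit, > 25000 nM. Compound 2 likewise gives only a limit, > 25000 nM. For that reason a step that the two limits leave unreadable from compound 1 to compound 2 cannot be read. Compound 2 thus sits at the limit of > 25000 nM in this assay, at which 2 of the 2 values shown sit, without a number of its own. Compound 3 `O=C(Nc1cccc(-c2nc3ccccc3s2)c1)c1ccncc1Cl` is not yet measured; it differs from compound 2 by 3-chloropyridin-4-yl in place of 1-methylethenyl on a carbonyl carbon. Within the data shown here, no measured step bears on a change of this kind, and the single known step is unreadable, so no shift beyond the scatter is expected in either direction. Compound 3 is therefore estimated at 30000 nM (range 8000 nM to 100000 nM), which means an expected step that the limit leaves unreadable from compound 2 to compound 3.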

Compound 3, half-maximal effective concentration: > 25000 nM
Compound 3: no number, only a limit (the forecaster's own chance of this, stated with the estimate: 80%); the middle value is on the limit's open side.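

Among these compounds, compound 3 also gives only a limit, > 25000 nM, so no step among compound 1, compound 2 and compound 3 can be read. From the compounds shown here alone, whether any other group on the carbonyl carbon would give a readable value in this assay remains open.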